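The source may hold more compounds than are shown below. What is called first, only, known or untested is meant among the compounds shown, and "the series" means these compounds.

Measured compounds in an ADME assay on HEK293-A cells (Homo sapiens) for cytotoxicity, read by MTT assay, with a stated time of 48 h; a higher number here means a weaker inhibitor, a lower number a stronger inhibitor:
Compound 1 `CN(CCC#N)C[C@H]1CN(c2ccc(-n3cc(-c4ccccn4)cn3)c(F)c2)C(=O)O1` gives > 400 ug/mL, which is a limit of the assay and not a number.
Compound 2 `O=C1CCC(=O)N1C[C@H]1CN(c2ccc(-n3cc(-c4ccccn4)cn3)c(F)c2)C(=O)O1` gives > 400 ug/mL, again a limit of the assay.
Compound 3 `O=C1CNC(=O)N1C[C@H]1CN(c2ccc(-n3cc(-c4ccccn4)cn3)c(F)c2)C(=O)O1` gives > 400 ug/mL, also a limit of the assay.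

Compound 3 thus stands at the limit of this assay and carries no number of its own. All three measured values sit at that limit, as the limit of > 400 ug/mL in this assay, at which 3 of the 3 values shown sit, records, so the three steps among them, a step that the two limits leave unreadable from compound 1 to compound 2, a step that the two limits leave unreadable from compound 1 to compound 3 and a step that the two limits leave unreadable from compound 2 to compound 3, cannot be read in size or direction. Compound 4 `CCNC(=O)NC[C@H]1CN(c2ccc(-n3cc(-c4ccccn4)cn3)c(F)c2)C(=O)O1` differs from compound 3 by (ethylcarbamoyl)amino in place of 2,5-dioxoimidazolidin-1-yl on a saturated chain carbon bound to a saturated ring carbon. The measured steps bear on this change only in one way: each earlier exchange at the same place on the saturated chain carbon, whether to an amine or to a cyclic imide, left the value at the limit. Nothing therefore points to a readable step from compound 3 to compound 4, and the expectation is a number no higher from compound 3 to compound 4 (the limit leaves the size open), nothing beyond the scatter. Compound 4 is expected at about 400 ug/mL, with a range from 200 ug/mL to 800 ug/mL, and most likely it too will be reported only as a limit.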

Compound 4, half-maximal inhibitory concentration: 29 ug/mL
For compound 4 the middle estimate is 14-fold (1.14 log units) above the measured one; measured number outside the range, below it.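

In this assay, the place on the saturated chain carbon bound to a saturated ring carbon now proves able to move the read-out: (ethylcarbamoyl)amino in place of 2,5-dioxoimidazolidin-1-yl gives an at least 13-fold lower number from compound 3 to compound 4 (1.13 log units; beyond the scatter), in place of 2,5-dioxopyrrolidin-1-yl it gives an at least 13-fold lower number from compound 2 to compound 4 (1.13 log units; beyond the scatter), and in place of (2-cyanoethyl)(methyl)amino it gives an at least 13-fold lower number from compound 1 to compound 4 (1.13 log units; beyond the scatter). On these data alone, the true sizes of these steps stay open, since all three start from the same limit of the assay: the limit of > 400 ug/mL in this assay, at which 3 of the 4 values shown sit. An open chain at this place is not enough on its own to give a readable value, as compound 1 also carries one and gives > 400 ug/mL, which is a limit of the assay.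

The compounds shown do not separate the ethyl end of (ethylcarbamoyl)amino from its carbonyl and amide hydrogens, so an acetylamino group or a longer chain such as (propylcarbamoyl)amino at the same place would bear on which part of it goes with the lower number. As far as these compounds go, whether the same exchange would give a similar step on a different core also remains open.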